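Trimming an aryl group to a single fluorine

The source may hold more compounds than are shown below. What is called first, only, known or untested is meant among the compounds shown, and "the series" means these compounds.

Two carbamate-type inhibitors of acid ceramidase open this account. Compound 1 `O=C(NCCCCc1ccccc1)n1c(=O)oc2cc(-c3ccc(F)cc3)ccc21` was measured in an assay on HEK293 cells for inhibition of acid ceramidase (Homo sapiens), with a stated time of 10 min (a higher number here means a weaker inhibitor, a lower number a stronger inhibitor), and gave 79 nM. Compound 2 `CCCc1ccc(CNC(=O)n2c(=O)oc3ccccc32)cc1` in this assay gave 19 nM. Of the two numbers on hand, compound 1 stands at the higher one; the gap to compound 2 lies beyond the usual scatter, so compound 2 is the stronger inhibitor of this pair. Within the data shown here, the two compounds differ in more than one place, so no single step can be drawn between them.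

The unmeasured compound 3 `O=C(NCCCCc1ccccc1)n1c(=O)oc2cc(F)ccc21` keeps the side chain of compound 1 and changes only the core: fluoro in place of 4-fluorophenyl on an aromatic carbon. Among the measured compounds shown here, nothing among the measured compounds isolates this change, so the direction of the step is uncertain. Compound 3 is expected to be a somewhat weaker inhibitor than compound 1 because the substituted core of compound 1 gave 79 nM, and the step is estimated as a 1.6-fold higher number from compound 1 to compound 3 (0.22 log units; within the scatter). For compound 3 in this assay the estimate is 130 nM, within a range from 40 nM to 400 nM.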

Compound 3, half-maximal inhibitory concentration: 31 nM
Compound 3: the middle estimate sits 4.2-fold (0.62 log units) above what was measured; measured number outside the range, below it.
By their numbers in this assay, from the lowest: compounds 2 and 3 (each within the scatter of the next); then compound 1.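

With the side chain held constant, putting fluoro in place of 4-fluorophenyl on this aromatic carbon gives in this assay a 2.5-fold lower number from compound 1 to compound 3 (0.41 log units; beyond the scatter), a modest step and the first in this account to isolate a single position. It shows that the six-membered aromatic ring of the 4-fluorophenyl group is not needed for inhibition at this place on the shared core: the single fluorine, with far fewer heavy atoms, gives the stronger inhibitor of this pair. The data shown offer no measurement that explains the gain, so the step stands as an observation only.

The compounds shown leave open whether the gain comes from losing the aromatic ring or from the fluorine itself, a question that a hydrogen, a chlorine or a methoxy group on the same carbon, with the same side chain, would help to separate. They also leave open whether the same change would give a step of similar size on the side chain of compound 2, which differs from compound 3 in more than one place and so cannot settle either question.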